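From 4-(trifluoromethyl)phenyl to 3-nitrophenyl: What to Expect

A few compounds are considered here, and "the series" means these few. Any claim that something is new, unique, unknown or untested is made for them only; others in the source may bear on it.

Two related compounds have been tested so far, and only one of them gave an exact number. For the measured compounds named here, in an ADME assay on MCF7-DOX cells (Homo sapiens) for cytotoxicity, read by MTT assay, with a stated time of 48 h (a higher number here means a weaker inhibitor, a lower number a stronger inhibitor), compound 1 `COc1cc(OC)c(C(=O)/C=C/c2ccc(C(F)(F)F)cc2)c(O)c1CC=C(C)C` gives 73700 nM, and that is the only true number available for comparison. Compound 2 `COc1cc(OC)c(C(=O)/C=C/c2ccc(N3CCN(C(=O)OC(C)(C)C)CC3)cc2)c(O)c1CC=C(C)C` gives > 100000 nM, which is a limit of the assay and not a number.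

The next compound to be tested is compound 3 `COc1cc(OC)c(C(=O)/C=C/c2cccc([N+](=O)[O-])c2)c(O)c1CC=C(C)C`. It keeps the shared core of compound 1 and carries 3-nitrophenyl in place of 4-(trifluoromethyl)phenyl on a double-bonded chain carbon bound to a double-bonded chain carbon.

Going by the values given here, no two measured compounds differ in just one place, so the data offer no direct guide to the size of such a change. Among the compounds with values here, the only anchor is compound 1 at 73700 nM. For that reason, no step beyond the usual scatter of this assay is expected, in either direction. The estimated change is a 1.2-fold lower number from compound 1 to compound 3 (0.09 log units; within the scatter). The estimate for compound 3 is 60000 nM, with an expected range from 25000 nM to 100000 nM.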

Compound 3, half-maximal inhibitory concentration: 57000 nM
Compound 3: middle estimate off by 1.1-fold (0.02 log units), on the high side; the range from low to high includes it.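

For the compounds shown here, this is the first step that can be read directly, since compound 1 and compound 3 differ in one place only. In this assay, putting 3-nitrophenyl in place of 4-(trifluoromethyl)phenyl on a double-bonded chain carbon bound to a double-bonded chain carbon gives a 1.3-fold lower number from compound 1 to compound 3 (0.11 log units; within the scatter), so this assay does not tell the two groups apart, even though the group that enters brings a nitrogen, two oxygens and 2 hydrogen-bond acceptors, while the group that leaves has 0 hydrogen-bond acceptors. Compound 2 remains a limit of the assay and not a number, so no step involving it can be read: the limit of > 100000 nM in this assay, at which 1 of the 3 values shown sits.

Two groups that give matching results are a small sample, and they say nothing about how far this place tolerates change in general. As far as these compounds go, it remains open whether an amine or a carboxylic acid on this ring would move the number beyond the scatter, and whether a longer chain in this same place would do so.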